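A few compounds are considered here, and "the series" means these few. Any claim that something is new, unique, unknown or untested is made for them only; others in the source may bear on it.

Compounds measured so far in an assay for inhibition of Indoleamine 2,3-dioxygenase 1 (Homo sapiens), with stated times of 10 min and 60 min; a lower number here means a stronger inhibitor, a higher number a weaker inhibitor:
compound 1, `O=C1NCc2c(NCc3ccccc3[N+](=O)[O-])cccc21`: > 100000 nM
compound 2, `O=C(O)CNc1cccc(CNc2cc(C(F)(F)F)cc3[nH]ncc23)c1`: > 100000 nM

Compound 1 gives only a limit in this assay; the figure shown is the edge of what the assay can report, not a measured number. The same holds for compound 2, which also reaches no more than the assay's limit. This is the whole of what the data show: the limit of > 100000 nM in this assay, at which 2 of the 2 values shown sit. Among the measured compounds shown here, compound 2 therefore cannot be placed on a scale at all; it stands at the reporting edge, as does the only other value shown.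

Compound 3, `CNC(=O)c1cccc(CNc2cc(C(F)(F)F)cc3[nH]ncc23)c1`, differs from compound 2 in one place: methylcarbamoyl in place of (carboxymethyl)amino on an aromatic carbon. No pair of measured compounds differing in a single place exists here, so the size of the change from compound 2 to compound 3 in this assay has no precedent among the numbers shown. Since compound 2 sits at the limit, the expected step is a number no higher from compound 2 to compound 3 (the limit leaves the size open), meaning none beyond the scatter, with compound 3 expected to remain at or near that same limit. For compound 3 the estimate in this assay is 100000 nM, with a range from 20000 nM to 300000 nM.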

Compound 3, half-maximal inhibitory concentration: > 100000 nM
Compound 3: a limit, no number (the forecaster's own chance of this, stated with the estimate: 75%); the middle value lies on the limit itself.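

In this assay compound 3 gives only a limit of > 100000 nM and not a number. Compound 2 also stands at a limit, so no step can be read between compound 2 and compound 3. The compounds shown leave open how strongly each one inhibits the enzyme, and whether methylcarbamoyl in place of (carboxymethyl)amino changes that inhibition at all.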